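A Hydrazide Ether Gives Way to an Ethenyl Ester

The source may report more compounds than this note shows. Statements on the series, on what has been measured and on what is new or still open speak of the compounds shown alone.

Of the compounds shown here, two sharing one core have been measured in an assay on a protein complex for inhibition of CDK8/Cyclin C (Homo sapiens), with a stated time of 1 h, tested at 10 uM; a lower number here means less inhibition, a higher number more inhibition at the concentration tested (going by the name of the read-out). Compound 1 `CN1CCN(C(=O)/C=C/c2ccncc2-c2ccc3ccccc3c2)CC1` gives 101% in this assay, while compound 2 `NNC(=O)COc1ccncc1-c1ccc2ccccc2c1` gives 19%, the lowest of the two numbers and a gap beyond the usual scatter.

Compound 3 `CCOC(=O)/C=C/c1ccncc1-c1ccc2ccccc2c1` has not yet been measured. It is derived from compound 2 by the change (2-(ethoxycarbonyl)ethenyl in place of (aminocarbamoyl)methoxy on an aromatic carbon), on the aromatic carbon opposite the ring nitrogen, ortho to a large group.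

Going by the values given here, no measured pair isolates this change. Still, compound 3 resembles compound 1 in carrying an ethenyl-linked carbonyl at that carbon, so an upward step is expected in this assay from compound 2 to compound 3, estimated at a number 56 percentage points higher from compound 2 to compound 3 (beyond the scatter), because compound 1 gives 101% with such a group. Compound 3 is therefore expected to show about 75%, within a range from 45% to 98%.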

Compound 3, a percentage reported as inhibition, at one concentration (the size of the read-out at that concentration, not a potency): 102%
Compound 3: the middle estimate sits 27 percentage points below what was measured; measured number outside the range, above it.
By their numbers in this assay, from the lowest: compound 2; then compounds 1 and 3 (each within the scatter of the next).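

In this assay, going by these compounds alone, the change to 2-(ethoxycarbonyl)ethenyl in place of (aminocarbamoyl)methoxy on the aromatic carbon opposite the ring nitrogen gives a number 83 percentage points higher from compound 2 to compound 3 (beyond the scatter) and is the first step measured at this position. With ethoxy in place of 4-methylpiperazin-1-yl on the carbonyl carbon, the comparison reads a number 1 percentage points higher from compound 1 to compound 3 (within the scatter) and so does not separate these two groups at the concentration tested. No supporting measurement bears on the size of the large step.

Because the ether linkage, the hydrazide and the ethenyl all differ within one change, the compounds shown leave open which part accounts for the step. They also leave open whether a carboxylic acid or a primary amide on the ethenyl chain, or a saturated ethyl chain carrying the ester, would read the same way at this position.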